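Swapping phenoxy for tert-butyl on a carbamate series

This account rests on a few compounds, and the source may have more. Where it says the series, first, only, none or still open, it means among the compounds named here.

Measured so far:
Compound 1 `CN(C)CCC(OC(=O)Nc1ccc(-c2ccccc2)cc1)c1ccc(Cl)cc1` — 269 nM
Compound 2 `CN(C)CCC(OC(=O)Nc1ccc(Oc2ccccc2)cc1)c1ccc(Cl)cc1` — 191 nM

In an assay on NIH3T3 cells with Urotensin-2 receptor (Homo sapiens) as the target (on this read-out higher numbers stand for an effect only at larger amounts of compound and lower numbers for an effect already at smaller amounts), compound 1 gives 269 nM and compound 2 gives 191 nM. Compound 2 carries the smaller of the two numbers, but the step of a 1.4-fold lower number from compound 1 to compound 2 (0.15 log units; within the scatter) is within the scatter, so the two compounds cannot be told apart on this evidence.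

Compound 3 `CN(C)CCC(OC(=O)Nc1ccc(C(C)(C)C)cc1)c1ccc(Cl)cc1` differs from compound 2 by tert-butyl in place of phenoxy on an aromatic carbon. Among the compounds with values here, only one measured step bears on this position: the exchange of phenyl for phenoxy, a 1.4-fold lower number from compound 1 to compound 2 (0.15 log units; within the scatter), which barely moved the number. Tert-butyl has no measured counterpart, so the new step is less certain than that one. Since two different groups at this place gave almost the same result, compound 3 is expected to show no step beyond the scatter, with the estimated step being a 1.3-fold higher number from compound 2 to compound 3 (0.12 log units; within the scatter). The estimate for compound 3 in this assay is therefore 250 nM, expected to lie between 80 nM and 800 nM.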

Compound 3, half-maximal effective concentration: 1820 nM
Estimate against measurement, compound 3: 7.3-fold (0.86 log units) below, outside the stated range (above it).
By their numbers in this assay, from the lowest: compounds 2 and 1 (each within the scatter of the next); then compound 3.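

In this assay tert-butyl in place of phenoxy gives a 9.5-fold higher number from compound 2 to compound 3 (0.98 log units; beyond the scatter) and tert-butyl in place of phenyl gives a 6.8-fold higher number from compound 1 to compound 3 (0.83 log units; beyond the scatter) so this position does respond to the group it carries. Phenyl and phenoxy, which both contain a six-membered aromatic ring, stay within the scatter of each other, whereas tert-butyl, which has no ring, gives the clearly higher number. Nothing available explains this difference.

The three compounds leave open whether an aromatic ring at this place is what matters, or whether other features of these groups decide the result; cyclohexyl, a ring that is not aromatic, would help separate these possibilities. On these data alone, how an amine or a carboxylic acid would fare at this place also remains open.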